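The source may hold more compounds than are shown below. What is called first, only, known or untested is meant among the compounds shown, and "the series" means these compounds.

Measured in a functional assay on U-937 cells (Homo sapiens) for antiproliferative activity, read by MTT assay, with a stated time of 24 h (on this read-out higher numbers stand for weaker inhibition and lower numbers for stronger inhibition), so far:
compound 1 `CCCCc1oc2ccccc2c1C(=O)c1ccc(OCC(=O)NC(C)C)cc1` gives 17500 nM
compound 2 `CCCCc1oc2ccccc2c1C(=O)c1ccc(OCC(=O)NCc2ccccc2)cc1` gives 16300 nM

Compound 2 stands level with compound 1 within the scatter, so neither leads. Compound 3 `CCCCc1oc2ccccc2c1C(=O)c1ccc(OCCCC(=O)N2CCOCC2)cc1` differs from compound 2 by 2-((morpholin-4-yl)carbonyl)ethyl in place of benzylcarbamoyl on a saturated chain carbon bound to an oxygen on an aromatic ring in one place, with 2-((morpholin-4-yl)carbonyl)ethyl in place of benzylcarbamoyl. Among the measured compounds shown here, the one measured step bearing on this is a 1.1-fold lower number from compound 1 to compound 2 (0.03 log units; within the scatter) for benzyl in place of isopropyl on an amide-type nitrogen, and it is only a weak guide to this wider change. In this assay no shift beyond the scatter is therefore expected, in either direction. The expected step is a 1.1-fold higher number from compound 2 to compound 3 (0.04 log units; within the scatter) as estimated here. For compound 3 the estimate is 18000 nM with an expected range from 8000 nM to 40000 nM on this read-out.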

Compound 3, half-maximal inhibitory concentration: 21400 nM
The estimate for compound 3 lay 1.2-fold (0.08 log units) below the measured number, and the stated range covers the measured number.
By their numbers in this assay, from the lowest: compounds 2, 1 and 3 (each within the scatter of the next).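

In this assay, 2-((morpholin-4-yl)carbonyl)ethyl in place of benzylcarbamoyl on a saturated chain carbon bound to an oxygen on an aromatic ring gives (a 1.3-fold higher number from compound 2 to compound 3 (0.12 log units; within the scatter)), and in place of isopropylcarbamoyl it gives (a 1.2-fold higher number from compound 1 to compound 3 (0.09 log units; within the scatter)). Thus, at this place, a change wider than the earlier one on the amide-type nitrogen, which also gives up the amide hydrogen and the aromatic ring of benzylcarbamoyl, still leaves all three compounds level. No measurement offers an explanation for this. From the compounds shown here alone, whether a carboxylic acid or an amine at this place would shift the number beyond the scatter remains open.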